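Swapping 3-methoxyphenyl for anilino on a carbonyl carbon

The compounds below may be only part of what the source reports. "The series", "measured", "known", "first", "only" and "open" are said of these compounds alone.

Values so far in a functional assay on A549 cells (Homo sapiens) for antiproliferative activity, read by MTT assay, with a stated time of 72 h; a higher number here means a weaker inhibitor, a lower number a stronger inhibitor
Compound 1 `CN(C(=O)c1ccc(F)cc1)c1ccc2[nH]c(-c3n[nH]c4ccccc34)cc2n1` gives 9650 nM
Compound 2 `COc1cccc(C(=O)N(C)c2ccc3[nH]c(-c4n[nH]c5ccccc45)cc3n2)c1` gives 14900 nM

Compound 2 has only compound 1 to be compared with, and the two cannot be told apart (a 1.5-fold higher number from compound 1 to compound 2 (0.19 log units; within the scatter)). On present numbers, compound 2 therefore stands level with compound 1.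

The next compound, compound 3 (`CN(C(=O)Nc1ccccc1)c1ccc2[nH]c(-c3n[nH]c4ccccc34)cc2n1`), keeps the shared core and changes one group (anilino in place of 3-methoxyphenyl on a carbonyl carbon): anilino in place of 3-methoxyphenyl on a carbonyl carbon. The same difference, cut one bond further out, reads (3-methoxyphenyl)carbonyl to phenylcarbamoyl.

Within the data shown here, only one measured step bears on this, the swap of 4-fluorophenyl for 3-methoxyphenyl on a carbonyl carbon, and it stayed within the scatter. Among the measured compounds shown here, it is a weak guide, since no measured compound carries anilino at this place. No step beyond the scatter is expected in this assay in either direction, though the range must stay wide.

The expected step is small (a 1.4-fold lower number from compound 2 to compound 3 (0.13 log units; within the scatter)). The estimated value for compound 3 is 11000 nM (expected range 4000 nM to 30000 nM).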

Compound 3, half-maximal inhibitory concentration: 1430 nM
Beside the measured number, compound 3's estimate is 7.7-fold (0.89 log units) above it, and the stated range ends above it.
By their numbers in this assay, from the lowest: compound 3; then compounds 1 and 2 (each within the scatter of the next).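

In this assay, this place on the carbonyl carbon proves able to shift the number well beyond the scatter, which the earlier pair of compounds did not show: anilino brings a 10-fold lower number from compound 2 to compound 3 (1.02 log units; beyond the scatter) and also a 6.7-fold lower number from compound 1 to compound 3 (0.83 log units; beyond the scatter). All three compounds carry a six-membered aromatic ring of carbon only here, while anilino brings a nitrogen and a hydrogen-bond donor that 3-methoxyphenyl does not have, so the step comes with a change in what is attached to the carbonyl carbon rather than with the loss of the ring. Nothing available explains why this swap lowers the number, and a link between the donor and the result remains only an observation from these few compounds.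

The compounds shown leave open whether the nitrogen itself or its hydrogen goes with the lower number, a question that a methylated anilino group, which keeps the nitrogen but has no such hydrogen, could address. They also leave open whether the ring of the anilino group accepts further groups, as 4-fluoroanilino or 3-methoxyanilino would show.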